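This account rests on a few compounds, and the source may have more. Where it says the series, first, only, none or still open, it means among the compounds named here.

Measured in an ADME assay on CCRF-CEM cells (Homo sapiens) for cytotoxicity; a lower number here means that less compound is tolerated, a higher number that more compound is tolerated:
Compound 1, `O=C(NCCO)c1cnc2ccccc2c1Cl`, gives > 100 uM, which is a limit of the assay and not a number.
Compound 2, `COC(=O)CNC(=O)c1cnc2ccccc2c1Cl`, gives > 100 uM, again a limit of the assay.
Compound 3, `COC(=O)[C@H](C)NC(=O)c1cnc2ccccc2c1Cl`, gives 81.3 uM.

Compound 1 therefore stands at the limit of > 100 uM in this assay, at which 2 of the 3 values shown sit, and no number is known for it; only compound 3 has a number, and that one lies close to the same limit. The unmeasured compound 4, `CCOC(=O)[C@H](CO)NC(=O)c1cnc2ccccc2c1Cl`, differs from compound 1 by ethoxycarbonyl in place of hydrogen on a saturated chain carbon bound to an amide-type nitrogen and a saturated chain carbon. For the measured compounds named here, three measured steps bear on this change. From the same chain carbon, the change a step that the two limits leave unreadable from compound 1 to compound 2 shows what adding an ester there did; the change an at least 1.2-fold lower number from compound 1 to compound 3 (0.08 log units; that floor lies within the scatter) and the change an at least 1.2-fold lower number from compound 2 to compound 3 (0.08 log units; that floor lies within the scatter) show what adding a methyl on that carbon did, and both stay inside the scatter. Nothing among these steps moved the tolerated concentration beyond the scatter, so for compound 4 no step beyond the scatter is expected in this assay, in either direction, and a further limit is quite possible. Compound 4 is accordingly estimated at 95 uM, with a range of 45 uM to 200 uM, which means an expected step of an at least 1.0-fold lower number from compound 1 to compound 4 (0.02 log units; that floor lies within the scatter).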

Compound 4, half-maximal toxic concentration: > 100 uM
Compound 4: no number, only a limit; the forecaster's own chance of this, stated with the estimate: 60%; at least 1.0-fold (0.02 log units) between middle value and limit.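

In this assay compound 4 gives > 100 uM, which is a limit of the assay and not a number. For the compounds shown here, compound 1 also has only a limit, so no step between compound 1 and compound 4 can be read. The compounds shown leave open how far ethoxycarbonyl in place of hydrogen shifts the tolerated concentration, with most values gathered at one point: the limit of > 100 uM in this assay, at which 3 of the 4 values shown sit.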